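Butyl Replaces Tert-Butyl on the Aromatic Carbon

A few compounds are considered here, and "the series" means these few. Any claim that something is new, unique, unknown or untested is made for them only; others in the source may bear on it.

The four compounds share one core and differ in the group on an aromatic carbon. Compound 1 `CCCCCc1ccc(NS(=O)(=O)c2ccc(N3CCNC3=O)cc2)cc1` carries a pentyl group, and in a functional assay on M21 cells (Homo sapiens) for antiproliferative activity, read by sulforhodamine B assay, with a stated time of 48 h (on this read-out lower numbers stand for stronger inhibition and higher numbers for weaker inhibition), compound 1 gives 870 nM. Compound 2 `O=C1NCCN1c1ccc(S(=O)(=O)Nc2ccc(I)cc2)cc1` carries iodo in its place, and in this assay compound 2 gives 260 nM, a change of a 3.3-fold lower number from compound 1 to compound 2 (0.52 log units; beyond the scatter). Compound 3 `CC(C)(C)c1ccc(NS(=O)(=O)c2ccc(N3CCNC3=O)cc2)cc1` carries tert-butyl. In this assay compound 3 gives only a limit of the assay, > 1000 nM. Compound 3 therefore stands at the limit of > 1000 nM in this assay, at which 1 of the 3 values shown sits, so the steps of an at least 1.1-fold higher number from compound 1 to compound 3 (0.06 log units; that floor lies within the scatter) and an at least 3.8-fold higher number from compound 2 to compound 3 (0.58 log units; beyond the scatter) are bounded on one side only.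

Compound 4 `CCCCc1ccc(NS(=O)(=O)c2ccc(N3CCNC3=O)cc2)cc1` differs from compound 3 by butyl in place of tert-butyl on an aromatic carbon. Going by the values given here, no measured step exchanges a branched chain for a straight one; the closest comparison is compound 1, whose pentyl chain gave 870 nM. Compound 4 is expected to give about 1000 nM, within 450 nM to 2500 nM. This estimate means an expected step of a number no higher from compound 3 to compound 4 (the limit leaves the size open). Compound 3 has only a limit, and the true size of that step is therefore uncertain.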

Compound 4, half-maximal inhibitory concentration: 450 nM
Compound 4: the middle estimate sits 2.2-fold (0.35 log units) above what was measured; low and high end bracket the measured number.
By their numbers in this assay, from the lowest: compounds 2, 4 and 1 (each within the scatter of the next, the first and the last beyond it). At a limit, above all of these: compound 3.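

In this assay, the same four carbons joined as a straight butyl chain rather than a branched tert-butyl group make a measurable difference at this position, with an at least 2.2-fold lower number from compound 3 to compound 4 (0.34 log units; beyond the scatter). Compound 3 sits at a limit of the assay, so this step is bounded on one side only: the limit of > 1000 nM in this assay, at which 1 of the 4 values shown sits. Compound 4 cannot be ordered against either neighbour, with a 1.7-fold higher number from compound 2 to compound 4 (0.24 log units; within the scatter) and a 1.9-fold lower number from compound 1 to compound 4 (0.29 log units; within the scatter), even though the iodo and pentyl compounds themselves are separated by a 3.3-fold lower number from compound 1 to compound 2 (0.52 log units; beyond the scatter).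

The compounds shown leave open how chain length acts below butyl, as with propyl or ethyl, and above pentyl, as with hexyl. They also leave open whether another branched chain, such as isobutyl, would behave like tert-butyl or like butyl at this carbon.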